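The source may hold more compounds than are shown below. What is called first, only, known or untested is meant among the compounds shown, and "the series" means these compounds.

Measured compounds:
compound 1 `COC(=O)[C@@]1(C)CCC=C2[C@@H]1CC[C@@H](C)[C@]2(C)Cc1c[nH]c2c(Cl)cccc12`: 19000 nM
compound 2 `COC(=O)[C@@]1(C)CCC=C2[C@@H]1CC[C@@H](C)[C@]2(C)Cc1c(C)[nH]c2c(C)cccc12`: 16000 nM

In a functional assay on HBL-100 cells (Homo sapiens) for inhibition, read by sulforhodamine B assay, with a stated time of 48 h (on this read-out lower numbers stand for stronger inhibition of growth and higher numbers for weaker inhibition of growth), compound 2 gives 16000 nM, the lower of the two numbers recorded, while compound 1 gives 19000 nM, a gap that sits within the scatter, so no order between them can be read. Compound 3 `COC(=O)[C@@]1(C)CCC=C2[C@@H]1CC[C@@H](C)[C@]2(C)Cc1c(C)[nH]c2c(Cl)cccc12` departs from compound 2 by chloro in place of methyl on an aromatic carbon. Compound 1 already carries chloro at that place and does not separate from compound 2, so no step beyond the scatter is expected in this assay. Compound 3 is therefore estimated at 17000 nM, with a range from 8000 nM to 36000 nM, a step of a 1.1-fold higher number from compound 2 to compound 3 (0.03 log units; within the scatter).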

Compound 3, concentration for 50% growth inhibition: 22000 nM
Compound 3: middle estimate off by 1.3-fold (0.11 log units), on the low side, and the stated range covers the measured number.
By their numbers in this assay, from the lowest: compounds 2, 1 and 3 (each within the scatter of the next).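

In this assay chloro in place of methyl on an aromatic carbon can now be read directly, and it gives a 1.4-fold higher number from compound 2 to compound 3 (0.14 log units; within the scatter) in a single change. Methyl in place of hydrogen on an aromatic carbon gives a 1.2-fold higher number from compound 1 to compound 3 (0.06 log units; within the scatter) as a second single change. Neither swap, then, separates its pair of compounds on this read-out. The compounds shown leave open whether an amine or a carboxylic acid on that aromatic carbon would give a step beyond the scatter. Nothing available here bears on the reason for these results.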